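A few compounds are considered here, and "the series" means these few. Any claim that something is new, unique, unknown or untested is made for them only; others in the source may bear on it.

Measured compounds:
- compound 1, `CC1=CC[C@H](C(C)(C)NC(=S)N/N=C/c2ccc(O)cc2)CC1`; in a functional assay on 786-0 cells (Homo sapiens) for inhibition, read by sulforhodamine B assay, with a stated time of 48 h (on this read-out lower numbers stand for stronger inhibition of growth and higher numbers for weaker inhibition of growth), compound 1 reaches only the assay limit, > 100000 nM.
- compound 2, `CC1=CC[C@H](C(C)(C)NC(=S)N/N=C/c2ccccc2O)CC1`; compound 2 gives 12100 nM.
- compound 3, `CC1=CC[C@H](C(C)(C)NC(=S)N/N=C/c2cccc(Cl)c2)CC1`; compound 3 gives 26900 nM.

Among the two numbers that are not limits, compound 3 holds the higher one, with compound 2 nearest: a 2.2-fold higher number from compound 2 to compound 3 (0.35 log units; beyond the scatter). The next compound, compound 4, `CC1=CC[C@H](C(C)(C)NC(=S)N/N=C/c2ccc[nH]2)CC1`, differs from compound 3 in one place: 1H-pyrrol-2-yl in place of 3-chlorophenyl on a carbon with a double bond to nitrogen. The steps that exchange the group on that same carbon are an at least 3.7-fold lower number from compound 1 to compound 3 (0.57 log units; beyond the scatter), a step that starts from a limit, and a 2.2-fold higher number from compound 2 to compound 3 (0.35 log units; beyond the scatter), a modest one. Both exchanged one six-membered ring for another; none introduced a five-membered ring, so the expected step is modest and its direction uncertain. The estimate for compound 4 is 30000 nM, between 10000 nM and 100000 nM, meaning an expected step of a 1.1-fold higher number from compound 3 to compound 4 (0.05 log units; within the scatter).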

Compound 4, concentration for total growth inhibition: > 100000 nM
Compound 4: a limit, no number; the forecaster's own chance of this, stated with the estimate: 25%; middle value at least 3.3-fold (0.52 log units) away from the limit.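

In this assay, putting 1H-pyrrol-2-yl on this carbon gives weaker growth inhibition than either measured six-membered ring: an at least 3.7-fold higher number from compound 3 to compound 4 (0.57 log units; beyond the scatter) and an at least 8.2-fold higher number from compound 2 to compound 4 (0.91 log units; beyond the scatter). Going by these compounds alone, this is the first five-membered ring in the set, and it loses the measurable number that 3-chlorophenyl and 2-hydroxyphenyl give. Compound 4 sits at a limit shared with compound 1, so the step between them cannot be read: the limit of > 100000 nM in this assay, at which 2 of the 4 values shown sit.

From the compounds shown here alone, whether this loss belongs to five-membered rings in general or to 1H-pyrrol-2-yl alone remains open. A furan-2-yl group on this carbon would bear on that question.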